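Swapping benzamido for chloro on a cytotoxicity read-out

The source may hold more compounds than are shown below. What is called first, only, known or untested is meant among the compounds shown, and "the series" means these compounds.

Of the compounds shown here, three sharing one core have been tested in an ADME assay on HEp-2 cells (Homo sapiens) for cytotoxicity, read by MTT assay, with a stated time of 72 h; on this read-out lower numbers stand for stronger inhibition and higher numbers for weaker inhibition. Compound 1 `C=CCOc1cc(C2=C(c3cc(OC)c(OC)c(OC)c3)C(=O)C(O)C2)ccc1OC` gives only a limit of the assay, > 100 ug/mL. Compound 2 `COc1ccc(C2=C(c3cc(OC)c(OC)c(OC)c3)C(=O)C(O)C2)cc1NC(=O)c1ccccc1` likewise reaches only the limit > 100 ug/mL. Compound 3 `CCOC(=O)COc1ccc(C2=C(c3cc(OC)c(OC)c(OC)c3)C(=O)CC2O)cc1` also stops at the limit > 100 ug/mL. Compound 2 thus stands where every value shown stands: at the limit of > 100 ug/mL in this assay, at which 3 of the 3 values shown sit. Among the compounds with values here, the one measured step is a step that the two limits leave unreadable from compound 1 to compound 2; with both ends at the limit its size cannot be read. Compound 4 `COc1ccc(C2=C(c3cc(OC)c(OC)c(OC)c3)C(=O)C(O)C2)cc1Cl` differs from compound 2 by chloro in place of benzamido on an aromatic carbon. Within the data shown here, no measured step bears on this change, so no step beyond the scatter is expected, and the estimated step is a step that the limit leaves unreadable from compound 2 to compound 4. Compound 4 is expected to give about 150 ug/mL, between 60 ug/mL and 400 ug/mL, most likely again only a limit.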

Compound 4, half-maximal inhibitory concentration: < 1 ug/mL
Compound 4: no number, only a limit; the forecaster's own chance of this, stated with the estimate: 75%; at least 150-fold (2.17 log units) between middle value and limit.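

Chloro on this aromatic carbon, ortho to a methoxy group, is the first change on the shared core to move the result in this assay off the upper limit. Replacing benzamido gives an at least 100-fold lower number from compound 2 to compound 4 (2.00 log units; beyond the scatter), and replacing allyloxy at the same place gives an at least 100-fold lower number from compound 1 to compound 4 (2.00 log units; beyond the scatter). Both steps rest on limits of the assay, so they fix a minimum size, not an exact one.

The step between compound 1 and compound 2 cannot be read, so allyloxy and benzamido cannot be ordered. From the compounds shown here alone, what a bromo group, a methyl group or a free amine would give at this position stays open.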